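From 4-nitrophenyl to 2-nitrophenyl on a sulfonyl sulfur

A few compounds are considered here, and "the series" means these few. Any claim that something is new, unique, unknown or untested is made for them only; others in the source may bear on it.

- Compound 1 `N#C/C(=C\c1ccccc1OS(=O)(=O)c1ccccc1[N+](=O)[O-])C(=O)Nc1nnc(Cc2cccc3ccccc23)s1` gives 66%
- Compound 2 `N#C/C(=C\c1ccccc1OS(=O)(=O)c1ccccc1[N+](=O)[O-])C(=O)Nc1nnc(Cc2ccccc2)s1` gives 71%
- Compound 3 `N#C/C(=C\c1ccccc1OS(=O)(=O)c1ccc([N+](=O)[O-])cc1)C(=O)Nc1nnc(Cc2cccc(F)c2)s1` gives 65%

All three numbers come from a functional assay on RS4-11 cells (Homo sapiens) for inhibition, read by CCK-8 assay, with a stated time of 48 h, tested at 20 uM (a higher number here means more inhibition of growth at the concentration tested, a lower number less inhibition of growth), and they lie within the scatter of one another, so the data do not separate compound 3 from the other two. The next molecule, compound 4 `N#C/C(=C\c1ccccc1OS(=O)(=O)c1ccccc1[N+](=O)[O-])C(=O)Nc1nnc(Cc2cccc(F)c2)s1`, differs from compound 3 by a single change: 2-nitrophenyl in place of 4-nitrophenyl on a sulfonyl sulfur. The two have the same atoms, joined differently.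

Among the compounds with values here, no measured step makes this exact swap. Within the data shown here, the only measured step, a number 5 percentage points higher from compound 1 to compound 2 (within the scatter), lies elsewhere in the molecule and stays within the scatter. Compound 1 and compound 2 already carry 2-nitrophenyl, and both lie within the scatter of compound 3, which gives 65%. No step beyond the scatter is therefore expected in this assay. The estimated change is a number 2 percentage points higher from compound 3 to compound 4 (within the scatter), a small expected rise that would stay within the scatter. For compound 4 the expected value is 67%, with an estimated range from 55% to 79%.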

Compound 4, percent growth inhibition at one concentration: 68%
Compound 4: the middle estimate sits 1 percentage points below what was measured, within the range that was stated.
By their numbers in this assay, from the lowest: compounds 3, 1, 4 and 2 (each within the scatter of the next).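

With the 3-fluorophenyl end held fixed, moving to 2-nitrophenyl in place of 4-nitrophenyl on a sulfonyl sulfur is now measured directly in this assay and gives a number 3 percentage points higher from compound 3 to compound 4 (within the scatter), so this swap of two isomeric groups does not separate the pair. The other end of the molecule also tolerates change in this read-out: fluoro in place of hydrogen on an aromatic carbon gives a number 3 percentage points lower from compound 2 to compound 4 (within the scatter) and 3-fluorophenyl in place of naphthalen-1-yl gives a number 2 percentage points higher from compound 1 to compound 4 (within the scatter) as well. No supporting data bear on these results, so nothing can be said about what lies behind them.

As far as these compounds go, it remains open whether the swap would read the same with a phenyl or naphthalen-1-yl group at the other end. Also open, from the compounds shown here alone, is what an amine or a carboxylic acid in place of the nitro group would do.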